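The source may hold more compounds than are shown below. What is called first, only, known or untested is meant among the compounds shown, and "the series" means these compounds.

Measured compounds in a functional assay on HeLa cells (Homo sapiens) for cytotoxicity, read by MTT assay, with a stated time of 24 h; on this read-out higher numbers stand for weaker inhibition and lower numbers for stronger inhibition:

Compound 1 `C=CC1=C(C(=O)NCc2ccc(C)cc2)C(c2ccc(F)cc2)OC1` gives only a limit of > 100000 nM.
Compound 2 `C=CC1=C(C(=O)NCC(C)C)C(c2ccc(F)cc2)OC1` gives only a limit of > 100000 nM.
Compound 3 `C=CC1=C(C(=O)Nc2ccccc2OC)C(c2ccc(Cl)c(Cl)c2)OC1` gives only a limit of > 100000 nM.

Compound 2 therefore stands at the limit of this assay and nowhere more precise: its value is a limit, not a number, and the two other values shown are limits as well, as the limit of > 100000 nM in this assay, at which 3 of the 3 values shown sit, states. Going by the values given here, the one step among the measured compounds that differs in a single place, a step that the two limits leave unreadable from compound 1 to compound 2, is unreadable, since both ends sit at the limit.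

Compound 4 `C=CC1=C(C(=O)Nc2cccc(C)c2)C(c2ccc(F)cc2)OC1` differs from compound 2 by 3-methylphenyl in place of isobutyl on an amide-type nitrogen. Among the compounds with values here, the only step that bears on this change is the one from compound 1 to compound 2, and it gives no readable size. With every measured value at the limit, no step beyond the scatter in this assay can be expected in either direction, and compound 4 is expected to sit at the limit as well, a step that the limit leaves unreadable from compound 2 to compound 4. Compound 4 is thus estimated at 150000 nM, within 50000 nM to 500000 nM.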

Compound 4, half-maximal inhibitory concentration: "not active" (no number reported)
For compound 4 the study gives words and no number, and the estimate cannot be compared.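

No new step can be read between compound 2 and compound 4, because compound 4 is reported only in words and compound 2 gives only a limit: the limit of > 100000 nM in this assay, at which 3 of the 4 values shown sit. The compounds shown leave open whether exchanging isobutyl for 3-methylphenyl on the amide-type nitrogen changes cytotoxicity at all.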